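Swapping the Tetrazole Arm for a Thiadiazole on Sulfur

This account rests on a few compounds, and the source may have more. Where it says the series, first, only, none or still open, it means among the compounds named here.

Compound 1 `Cc1ccc(-c2cs/c(=N/NC(=O)CSc3nnnn3-c3ccccc3)n2-c2ccccc2)cc1`: 14.7 ug/mL in a functional assay on C6 cells (Rattus norvegicus) for cytotoxicity, read by MTT assay, with a stated time of 24 h; on this read-out lower numbers stand for stronger inhibition and higher numbers for weaker inhibition
Compound 2 `O=C(CSc1nnnn1-c1ccccc1)N/N=c1/scc(-c2ccc(Cl)cc2)n1-c1ccccc1`: only a limit, > 200 ug/mL, in this assay

Compound 1 holds the only number shown in this assay; the other value is a limit (the limit of > 200 ug/mL in this assay, at which 1 of the 2 values shown sits). Among the compounds with values here, the single measured step, an at least 13-fold higher number from compound 1 to compound 2 (1.13 log units; beyond the scatter), changes the aryl substituent and leaves the sulfur untouched. Compound 3 `Cc1ccc(-c2cs/c(=N/NC(=O)CSc3nnc(C)s3)n2-c2ccccc2)cc1` differs from compound 1 in 5-methyl-1,3,4-thiadiazol-2-yl in place of 1-phenyl-1H-tetrazol-5-yl on a sulfur. Within the data shown here, no measured step bears on this change, so the data give no direction for it, and compound 1 serves as the reference. Compound 3 is therefore expected near 25 ug/mL, between 8 ug/mL and 120 ug/mL. The expected step, a 1.7-fold higher number from compound 1 to compound 3 (0.23 log units; within the scatter), is estimated to stay within the scatter.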

Compound 3, half-maximal inhibitory concentration: 25.3 ug/mL
For compound 3 the middle estimate is 1.0-fold (0.01 log units) below the measured one, within the range that was stated.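

In this assay, within the data shown here, the exchange on the sulfur gives a 1.7-fold higher number from compound 1 to compound 3 (0.24 log units; within the scatter), the first step at this place, so the two arms read alike even though 5-methyl-1,3,4-thiadiazol-2-yl carries one aromatic ring where 1-phenyl-1H-tetrazol-5-yl carries two. Nothing at hand accounts for this likeness. On these data alone, it remains open whether the exchange would read the same with chloro in place of methyl on the aromatic carbon. Also open, as far as these compounds go, is how an arm with no aromatic ring, such as an amine or a carboxylic acid, would read on this sulfur.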